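The source may report more compounds than this note shows. Statements on the series, on what has been measured and on what is new or still open speak of the compounds shown alone.

Compounds measured so far:
Compound 1 `CCOc1ncccc1-c1c(C)nn(-c2nc(-c3ccc(Cl)c(Cl)c3)c(SC(C)C)s2)c1C(=O)O` gives 11000 nM.
Compound 2 `Cc1nn(-c2nc(-c3ccc(Cl)c(Cl)c3)c(SC(C)C)s2)c(C(=O)O)c1-c1cc(C(F)(F)F)cc(C(F)(F)F)c1` gives 1800 nM.

Both numbers come from a functional assay on BJAB cells (Homo sapiens) for antiproliferative activity, with a stated time of 4 days; on this read-out higher numbers stand for an effect only at larger amounts of compound and lower numbers for an effect already at smaller amounts. Among the compounds with values here, of the two, compound 1 stands at the highest number; its only neighbour, compound 2, sits at a lower number, and that gap lies beyond the scatter. Compound 3 `Cc1nn(-c2nc(-c3ccc(Cl)c(Cl)c3)c(SC(C)C)s2)c(C(=O)O)c1-c1ccccc1Cl` has not yet been measured in this assay. It differs from compound 1 in one place: 2-chlorophenyl in place of 2-ethoxypyridin-3-yl on an aromatic carbon. Within the data shown here, no pair of measured compounds shares this change, so the expectation can rest only on the two values shown and on the change itself. Because compound 2 gives 1800 nM, a move away from the ethoxypyridinyl group toward a plainer aromatic ring is expected to lower the number rather than raise it. The expected step is a 2.4-fold lower number from compound 1 to compound 3 (0.39 log units; beyond the scatter), modest but beyond the scatter. Compound 3 is estimated at 4500 nM, with a range from 1500 nM to 14000 nM.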

Compound 3, half-maximal effective concentration: 13100 nM
The estimate for compound 3 lay 2.9-fold (0.46 log units) below the measured number; the range from low to high includes it.
By their numbers in this assay, from the lowest: compound 2; then compounds 1 and 3 (each within the scatter of the next).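

In this assay, putting 2-chlorophenyl in place of 2-ethoxypyridin-3-yl on this aromatic carbon gives a 1.2-fold higher number from compound 1 to compound 3 (0.08 log units; within the scatter). Within the data shown here, this is the first direct reading at this position, and it shows that the two groups cannot be told apart here, although the entering ring is of carbon only and carries none of the hydrogen-bond acceptors counted on the leaving group. Nothing available explains why these two groups read alike. The compounds shown leave open whether the ring hetero atom and the ethoxy group each matter when changed alone, as a 2-ethoxyphenyl or a pyridin-3-yl group would show. They also leave open how an unsubstituted phenyl or a ring bearing an amine would read at this position.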